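Pyrrolidin-1-yl to piperidin-1-yl: clearance outlook for compound 3

The source may report more compounds than this note shows. Statements on the series, on what has been measured and on what is new or still open speak of the compounds shown alone.

Going by the values given here, compound 2 `Fc1ccccc1Cn1nc(-c2ncc(F)c(N3CCCC3)n2)cc1-c1ccon1` gives the highest of the two numbers so far in an ADME assay on microsomes from liver (Rattus norvegicus) for pharmacokinetics (on this read-out higher numbers stand for fast clearance and lower numbers for slow clearance), at 500 uL/min; compound 1 `CNc1nc(-c2cc(-c3ccon3)n(Cc3ccccc3F)n2)ncc1F` gives 160 uL/min. Among the compounds with values here, the single step in hand, a 3.1-fold higher number from compound 1 to compound 2 (0.49 log units; beyond the scatter), shows pyrrolidin-1-yl in place of methylamino moving the number beyond the scatter. Compound 3 `Fc1ccccc1Cn1nc(-c2ncc(F)c(N3CCCCC3)n2)cc1-c1ccon1` differs from compound 2 as follows: piperidin-1-yl in place of pyrrolidin-1-yl on an aromatic carbon. Within the data shown here, no measured pair tests this change directly, so the step from compound 1 to compound 2 bears on it only loosely. For compound 3 a step within the scatter or a slight rise is expected, a 1.2-fold higher number from compound 2 to compound 3 (0.08 log units; within the scatter). Compound 3 is therefore estimated at 600 uL/min, with a range from 300 uL/min to 1200 uL/min.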

Compound 3, intrinsic clearance in a liver preparation (reported as CLH), per the amount of preparation that the assay uses: 490 uL/min
Compound 3: the middle estimate sits 1.2-fold (0.09 log units) above what was measured; measured number inside the range.
By their numbers in this assay, from the lowest: compound 1; then compounds 3 and 2 (each within the scatter of the next).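

In this assay, going from the five-membered to the six-membered ring at this aromatic carbon changes little, with a 1.0-fold lower number from compound 2 to compound 3 (0.01 log units; within the scatter). The rise over methylamino is therefore not confined to pyrrolidin-1-yl, since piperidin-1-yl gives a 3.1-fold higher number from compound 1 to compound 3 (0.49 log units; beyond the scatter). Nothing measured here explains why the two rings read alike.

Open, from the compounds shown here alone, is whether the higher number needs a ring at all, a question that dimethylamino at this carbon would address. Also open, going by these compounds, is whether morpholin-4-yl, with a ring oxygen, would stay level with the two rings.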